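The source may report more compounds than this note shows. Statements on the series, on what has been measured and on what is new or still open speak of the compounds shown alone.

Compound 1 `CCc1cccc(NS(=O)(=O)c2ccc(N3CCNC3=O)cc2)c1` is the starting point. Among the measured compounds shown here, in a functional assay on P388D1 cells (Homo sapiens) for antiproliferative activity, read by sulforhodamine B assay, with a stated time of 48 h (on this read-out lower numbers stand for stronger inhibition and higher numbers for weaker inhibition), compound 1 gives 250 nM, the higher of the two numbers known so far. Compound 2 `COc1cc(NS(=O)(=O)c2ccc(N3CCNC3=O)cc2)cc(OC)c1OC` gives a lower 38 nM, a gap beyond the usual scatter of repeated measurements.

Compound 3 `O=C1NCCN1c1ccc(S(=O)(=O)Nc2cccc(Cl)c2)cc1` keeps the core of compound 1 and changes a single group: chloro in place of ethyl on an aromatic carbon. In words, chloro takes the place of ethyl on an aromatic carbon, so 3-ethylphenyl becomes 3-chlorophenyl. For the measured compounds named here, no two measured compounds differ in one place only, so the data offer no direct guide to this swap. In this assay no change beyond the scatter is expected. The expected step of a 1.2-fold higher number from compound 1 to compound 3 (0.08 log units; within the scatter) is small, leaning slightly toward a higher number. Compound 3 is estimated at 300 nM, with an expected range of 100 nM to 900 nM.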

Compound 3, half-maximal inhibitory concentration: 78 nM
The estimate for compound 3 lay 3.8-fold (0.59 log units) above the measured number; the measured number lies below the stated range.
By their numbers in this assay, from the lowest: compound 2; then compound 3; then compound 1.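

In this assay, among the compounds shown here, chloro in place of ethyl gives a 3.2-fold lower number from compound 1 to compound 3 (0.51 log units; beyond the scatter) and is the first comparison here between two compounds that differ in one place only. It shows that the group on this aromatic carbon, meta to a large group, matters to the read-out, and that a single chlorine atom can serve better here than the two carbons of ethyl. No measurement shown here explains the step.

As far as these compounds go, what stays open is how far this trend runs, as one pair gives a direction for only these two groups; a fluoro, a methyl or an amine on the same carbon would show whether chloro is special. Compound 2 differs from compound 3 in more than one place, so the route from 3-chlorophenyl to its ring pattern also remains unresolved.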